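Removing the Methyl from Compound 3's Aryl Ether Oxygen

The source may hold more compounds than are shown below. What is called first, only, known or untested is meant among the compounds shown, and "the series" means these compounds.

The series is followed in an ADME assay on HEK293 cells (Homo sapiens) for cytotoxicity, read by reporter gene assay and resazurin assay, with a stated time of 48 h; a higher number here means that more compound is tolerated, a lower number that less compound is tolerated. Compound 1 `O=C(Nc1ccccc1)c1cc(Br)ccc1O` gives 35000 nM there. Compound 2 `COc1c(Br)cccc1C(=O)Nc1ccccc1` reaches only a limit of the assay, > 100000 nM. Compound 3 `COc1ccc(Br)cc1C(=O)Nc1ccc(Sc2nc3ccccc3s2)cc1` likewise returns only a limit, > 100000 nM; it therefore stands at the limit of > 100000 nM in this assay, at which 2 of the 3 values shown sit, with no number of its own. The compound yet to be measured is compound 4 `O=C(Nc1ccc(Sc2nc3ccccc3s2)cc1)c1cc(Br)ccc1O`, which differs from compound 3 by hydrogen in place of methyl on an oxygen on an aromatic ring. The closest guide is compound 1, which carries the same hydroxy group and gives a measured value rather than a limit. Compound 4 is therefore expected to tolerate less than the limit seen for compound 3, an expected step of an at least 2.5-fold lower number from compound 3 to compound 4 (0.39 log units; beyond the scatter). The estimated value for compound 4 is 40000 nM, within 10000 nM to 100000 nM.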

Compound 4, half-maximal cytotoxic concentration: 42000 nM
Compound 4: middle estimate off by 1.1-fold (0.02 log units), on the low side; low and high end bracket the measured number.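

In this assay, replacing methyl with hydrogen on this oxygen on an aromatic ring gives the series its first readable step: an at least 2.3-fold lower number from compound 3 to compound 4 (0.37 log units; beyond the scatter). This is a lower bound on the change because compound 3 has only a limit: the limit of > 100000 nM in this assay, at which 2 of the 4 values shown sit. Among the compounds shown, this change also gives the larger compound a measured value, as the hydroxy group of compound 1 does in the smaller one.

Going by these compounds, how far compound 3 really lies from compound 4 stays open. So does whether an ethoxy group or an amine at this place would behave like methoxy or like hydroxy.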